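Swapping the Aryl Cap on a Hydrazone Series

A few compounds are considered here, and "the series" means these few. Any claim that something is new, unique, unknown or untested is made for them only; others in the source may bear on it.

Compound 2 `COc1ccc(/C=N/NC(=O)CSc2nnc(-c3ccncc3)o2)cc1` was tested in a functional assay on MCF7 cells (Homo sapiens) for cytotoxicity, read by MTT assay, with a stated time of 48 h (a lower number here means a stronger inhibitor, a higher number a weaker inhibitor), where compound 2 gives 17600 nM. That is the highest of the three numbers at hand. The nearest is compound 3 `O=C(CSc1nnc(-c2ccncc2)o1)N/N=C/c1cccc(C(F)(F)F)c1`, which in this assay gives 14600 nM, a gap within the usual scatter. Furthest away is compound 1 `NNC(=O)CSc1nnc(-c2ccncc2)o1`, the free hydrazide, which in this assay gives 3260 nM, a gap beyond the scatter. Within the data shown here, no single-point step between two measured compounds can be drawn from these three.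

Compound 4 `O=C(CSc1nnc(-c2ccncc2)o1)N/N=C/c1cc(Br)ccc1O` has not yet been measured. Relative to compound 2 the change is 5-bromo-2-hydroxyphenyl in place of 4-methoxyphenyl on a carbon with a double bond to nitrogen. Among the measured compounds shown here, nothing among the measured compounds shows what this swap does, since compound 3 differs at the aryl cap in another way. Because compound 2 gives 17600 nM and compound 3 gives 14600 nM in this assay and these two aryl hydrazones sit close together, compound 4 is expected to land in the same region. The step expected is a 1.5-fold lower number from compound 2 to compound 4 (0.17 log units; within the scatter), a small one towards a lower number and not clearly beyond the scatter. The estimate for compound 4 in this assay is 12000 nM, with a range from 4000 nM to 36000 nM.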

Compound 4, half-maximal inhibitory concentration: 7770 nM
Estimate against measurement, compound 4: 1.5-fold (0.19 log units) above; measured number inside the range.
By their numbers in this assay, from the lowest: compound 1; then compounds 4, 3 and 2 (each within the scatter of the next, the first and the last beyond it).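

In this assay, among these compounds, the aryl cap on a carbon with a double bond to nitrogen proves able to move the number: the change to 5-bromo-2-hydroxyphenyl in place of 4-methoxyphenyl gives a 2.3-fold lower number from compound 2 to compound 4 (0.36 log units; beyond the scatter) and is the first single-point step that can be read, a modest one. The entering group brings both a bromine and a hydrogen-bond donor that the leaving group lacks, so this single step cannot divide its size between them. Nothing at hand bears on why the number falls.

Going by these compounds, what a cap with the hydroxyl alone or the bromine alone would give remains open. So does the outcome of an amine or a carboxylic acid on that ring, or of a longer chain in place of the aryl cap.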